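Methyl Added to a Ketone Core in a Cytotoxicity Assay

The source may report more compounds than this note shows. Statements on the series, on what has been measured and on what is new or still open speak of the compounds shown alone.

Compound 1 `OCCCCCC(O)c1ccc(-c2ccccc2)cc1`: 22000 nM
Compound 2 `Cc1cccc(-c2ccc(C(O)CCCCCO)cc2)c1`: > 100000 nM
Compound 3 `O=C(CCCCCO)c1ccc(-c2ccccc2)cc1`: 22000 nM

Of the compounds shown here, three have been measured in a functional assay on J774 cells (Mus musculus) for cytotoxicity, read by resazurin assay; on this read-out higher numbers stand for weaker inhibition and lower numbers for stronger inhibition. Compound 1 gives 22000 nM. For compound 2 only a limit of the assay is reported, > 100000 nM, and no number is known there. Compound 3 gives 22000 nM, which sits level with compound 1 at the digits reported and within the usual scatter, so no order between the two can be drawn.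

For the measured compounds named here, the one step among the measured compounds, an at least 4.5-fold higher number from compound 1 to compound 2 (0.65 log units; beyond the scatter), comes from a single change, (methyl in place of hydrogen on an aromatic carbon). That its size can only be given as a lower bound follows from the limit of > 100000 nM in this assay, at which 1 of the 3 values shown sits.

Compound 4 `Cc1cccc(-c2ccc(C(=O)CCCCCO)cc2)c1` has not yet been measured in this assay. It differs from compound 3 by methyl in place of hydrogen on an aromatic carbon, the same change made from compound 1 to compound 2, at a place described in the same words. How the core of compound 3 differs from the core of compound 1 is not broken down here.

For compound 4 a step of a 5.5-fold higher number from compound 3 to compound 4 (0.74 log units; beyond the scatter) is expected, resting on the measured step of an at least 4.5-fold higher number from compound 1 to compound 2 (0.65 log units; beyond the scatter) and on the value of compound 3, 22000 nM. Compound 4 is therefore estimated at 120000 nM, with an expected range from 45000 nM to 320000 nM, and a good chance that the assay again reports only a limit.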

Compound 4, half-maximal inhibitory concentration: 100000 nM
Beside the measured number, compound 4's estimate is 1.2-fold (0.08 log units) above it; measured number inside the range.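

In this assay, methyl in place of hydrogen on an aromatic carbon gives a 4.5-fold higher number from compound 3 to compound 4 (0.66 log units; beyond the scatter), so the number rises with this change on both cores shown, and the two steps set side by side read: the same change on two cores in this assay, an at least 4.5-fold higher number (0.65 log units; beyond the scatter) from compound 1 to compound 2 and a 4.5-fold higher number (0.66 log units; beyond the scatter) from compound 3 to compound 4; the limit leaves it open whether they differ The earlier step is only a lower bound, as compound 2 is reported at a limit of the assay and not at a number: the limit of > 100000 nM in this assay, at which 1 of the 4 values shown sits. The pair of cores therefore shows that the direction of the change carries over and that the step on the second core is beyond the scatter, but it does not show that the two steps are equal in size, nor that the change would act the same way on any core beyond these two.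

The compounds shown carry only methyl as the added group, always at the one place on the ring, so it stays open how a chlorine, a methoxy or an amine at that place would read in this assay, or how methyl would read elsewhere on the ring. Also open, from the compounds shown here alone, is whether the step would hold with a longer chain or with a carboxylic acid at the end of the chain in place of the hydroxyl.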